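The compounds below may be only part of what the source reports. "The series", "measured", "known", "first", "only" and "open" are said of these compounds alone.

Measured so far in a functional assay on MGC-803 cells (Homo sapiens) for inhibition, read by MTT assay, with a stated time of 48 h; a lower number here means a stronger inhibitor, a higher number a weaker inhibitor:
compound 1 `Cc1ccc(NC(=S)NC(=O)c2ccc(OCc3ccc(Cl)cc3Cl)cc2)cc1-c1nc2ccccc2[nH]1`, giving 3450 nM
compound 2 `O=C(NC(=S)Nc1ccc(Cl)c(-c2nc3ccccc3[nH]2)c1)c1ccc(OCc2ccc(Cl)cc2Cl)cc1`, giving 3030 nM
compound 3 `Cc1ccc(NC(=O)NC(=O)c2ccc(OCc3ccccc3F)cc2)cc1-c1nc2ccccc2[nH]1`, giving 2520 nM

Compound 4 `O=C(NC(=O)c1ccc(OCc2ccccc2F)cc1)Nc1ccc(Cl)c(-c2nc3ccccc3[nH]2)c1` has not yet been measured. From compound 1 to compound 2 the change is chloro in place of methyl on an aromatic carbon, and in this assay it made a 1.1-fold lower number from compound 1 to compound 2 (0.06 log units; within the scatter). From compound 3 to compound 4 the change is chloro in place of methyl on an aromatic carbon, the same change at the same kind of place. The difference between the core of compound 3 and the core of compound 1 is not broken down here. The three measured values lie within the scatter of one another, so no order among them is claimed. For compound 4 a step like the earlier one is expected in this assay, namely a 1.1-fold lower number from compound 3 to compound 4 (0.04 log units; within the scatter). For the measured compounds named here, that expectation rests on the single measured instance of the change, which gave a 1.1-fold lower number from compound 1 to compound 2 (0.06 log units; within the scatter). Compound 4 is estimated at 2300 nM, with a range from 1100 nM to 4800 nM.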

Compound 4, half-maximal inhibitory concentration: 120 nM
Compound 4: middle estimate off by 19-fold (1.28 log units), on the high side, outside the stated range (below it).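

In this assay, chloro in place of methyl on an aromatic carbon, ortho to a 1H-benzimidazol-2-yl group, gave a 21-fold lower number from compound 3 to compound 4 (1.32 log units; beyond the scatter). The size of the step did not carry from one core to the other: the same change on two cores in this assay, a 1.1-fold lower number (0.06 log units; within the scatter) from compound 1 to compound 2 and a 21-fold lower number (1.32 log units; beyond the scatter) from compound 3 to compound 4, 18-fold (1.27 log units) apart, beyond the scatter of two such steps. This shows that the step depends on its core in this pair of pairs, but it does not show which difference between the cores matters, and two pairs set no rule for other cores.

Still open is whether the large step goes with the carbonyl in place of the thiocarbonyl or with the different halogens on the two cores, as no pair shown changes either alone. Also open, as far as these compounds go, is how a nitrile or an amine in place of the chloro would behave on the core of compound 3.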